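This account rests on a few compounds, and the source may have more. Where it says the series, first, only, none or still open, it means among the compounds named here.

Working notes on a small series sharing one core. The parent, compound 2, `c1cnc2cc3c(cc2c1)C1CNCC3C1`, is measured in an assay for binding affinity to Neuronal acetylcholine receptor; alpha4/beta2 (Rattus norvegicus) (a lower number here means a stronger inhibitor, a higher number a weaker inhibitor), and gives 1.6 nM. Within the data shown here, compound 3, `c1ccc(-c2cnc3cc4c(cc3c2)C2CNCC4C2)cc1`, carries a phenyl on an aromatic carbon of the core and gives 132 nM; the single one-place step measured so far is an 83-fold higher number from compound 2 to compound 3 (1.92 log units; beyond the scatter). Compound 1, `c1cc(-c2cnc3cc4c(cc3n2)C2CNCC4C2)c[nH]1`, gives 360 nM. Among the three numbers, compound 3 stands second highest: compound 1 lies higher, compound 2 lies far lower.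

Compound 4, `CCc1cnc2cc3c(cc2c1)C1CNCC3C1`, is not yet measured. It differs from compound 3 by ethyl in place of phenyl on an aromatic carbon. The step that bears on it is an 83-fold higher number from compound 2 to compound 3 (1.92 log units; beyond the scatter), in which a six-membered aromatic ring of carbon only entered at this place of the core and the number rose strongly. With ethyl, two heavy atoms and no ring, the site is left in a state between the hydrogen of compound 2 and the phenyl of compound 3. Among the measured compounds shown here, no compound with a chain at this place has been measured, so the size of the effect is open. For compound 4 the expected step is estimated as a 6.6-fold lower number from compound 3 to compound 4 (0.82 log units; beyond the scatter), which would put its number below compound 3 yet above compound 2. The estimate for compound 4 in this assay is 20 nM, with a range from 5 nM to 80 nM.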

Compound 4, inhibition constant: 1.2 nM
Compound 4: the middle estimate sits 17-fold (1.22 log units) above what was measured; measured number outside the range, below it.
By their numbers in this assay, from the lowest: compounds 4 and 2 (each within the scatter of the next); then compound 3; then compound 1.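

In this assay this aromatic carbon, two atoms from the ring nitrogen, accepts a substituent with no readable effect on the number: ethyl in place of hydrogen gives a 1.3-fold lower number from compound 2 to compound 4 (0.12 log units; within the scatter) and so cannot be told apart from the parent. The strong rise seen earlier, an 83-fold higher number from compound 2 to compound 3 (1.92 log units; beyond the scatter) with phenyl, is therefore tied to phenyl and is not a general result of substitution here, and exchanging that phenyl for ethyl gives a 110-fold lower number from compound 3 to compound 4 (2.04 log units; beyond the scatter) and returns the number to the level of the parent. Phenyl and ethyl differ both in heavy-atom count and in the presence of a six-membered aromatic ring, and with no measurement at hand that explains the gap, these two differences stay unseparated.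

Open, on these data alone, is how far this tolerance reaches along a longer chain such as propyl or butyl, and whether a small non-aromatic ring such as cyclopropyl or cyclohexyl behaves like ethyl or like phenyl. Also open, as far as these compounds go, is how an amine or a carboxylic acid at this carbon would read in this assay for comparison with ethyl.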